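Cyclopropyl in Place of Tert-butyl on a Receptor Agonist Core

A few compounds are considered here, and "the series" means these few. Any claim that something is new, unique, unknown or untested is made for them only; others in the source may bear on it.

Measured so far:
Compound 1 `CC(C)(C)Cc1cnc(CCc2ccc(-c3ccccc3C(=O)O)cc2)[nH]1` — 106 nM
Compound 2 `CCCCc1cnc(CCCc2ccc(-c3ccccc3C(=O)O)cc2)[nH]1` — 5600 nM
Compound 3 `CCCCc1cnc(C(C)Cc2ccc(-c3ccccc3C(=O)O)cc2)[nH]1` — 2760 nM

The three compounds above were tested in an in vitro functional assay on cells for agonist activity at Bombesin receptor subtype-3 (Homo sapiens), read by luminescence and calcium flux; a higher number here means that more compound is needed for the effect, a lower number that less compound is needed. Compound 1 gives the lowest number of the three in this assay at 106 nM. The nearest of the others is compound 3, whose value of 2760 nM lies well beyond the usual scatter above that of compound 1, and compound 2, at 5600 nM, lies further still. Compounds 2 and 3 differ from compound 1 in more than one place, so no single structural change can be tied to those gaps.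

Compound 4 `O=C(O)c1ccccc1-c1ccc(CCc2ncc(CC3CC3)[nH]2)cc1` has not yet been measured in this assay. It differs from compound 1 in one place only: cyclopropyl in place of tert-butyl on a saturated chain carbon bound to an aromatic carbon.

No pair of measured compounds shows this change on its own, so its effect is not known from the numbers shown. The expectation is a modest move toward a higher number in this assay, of a size that may or may not clear the scatter. The step from compound 1 to compound 4 is estimated at a 2.8-fold higher number from compound 1 to compound 4 (0.45 log units; beyond the scatter), because compound 1 sits at 106 nM and the shared core is kept intact. Compound 4 is therefore expected to give about 300 nM, within a range from 100 nM to 1200 nM.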

Compound 4, half-maximal effective concentration: 1000 nM
For compound 4 the middle estimate is 3.3-fold (0.52 log units) below the measured one; the range from low to high includes it.
By their numbers in this assay, from the lowest: compound 1; then compound 4; then compound 3; then compound 2.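

In this assay the change from tert-butyl to cyclopropyl gives a 9.4-fold higher number from compound 1 to compound 4 (0.97 log units; beyond the scatter) with everything else in the molecule held the same. Within the data shown here, this is the first clean reading at this position, since compounds 2 and 3 differ from compound 1 in more than one place: the group on this saturated chain carbon matters on its own, and here neopentyl gives the lower number and cyclopropylmethyl the higher. The swap leaves the counts of hydrogen-bond donors, hydrogen-bond acceptors and net charge unchanged, and nothing measured here explains why the number moves.

The step also combines two differences, one carbon fewer and a closed ring, and this single pair cannot separate them; an isopropyl group in the same place would keep the open chain, while a cyclobutyl group would keep a ring. As far as these compounds go, it also remains open whether the same swap would act in the same way on compounds with a different link to the shared core, such as the longer chain of compound 2.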